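Adding a Methyl to the Chain of Compound 2

The source may report more compounds than this note shows. Statements on the series, on what has been measured and on what is new or still open speak of the compounds shown alone.

Compound 1 `C/N=C(\S)CCn1nc(-c2ccccc2)ccc1=O` gives 58.5 mg/kg in a functional assay on the whole organism (stomach) with Rattus norvegicus as the target; a lower number here means that less compound is needed, a higher number that more compound is needed for the effect.
Compound 2 `N=C(S)CCn1nc(-c2ccccc2)ccc1=O` gives 87.3 mg/kg in this assay.

Within the data shown here, of the two numbers measured so far, compound 2 gives the larger one, but the gap a 1.5-fold higher number from compound 1 to compound 2 (0.17 log units; within the scatter) lies within the scatter, so the two compounds cannot be told apart on these data. Compound 3 `CC(Cn1nc(-c2ccccc2)ccc1=O)C(=N)S` differs from compound 2 in one place: methyl in place of hydrogen on a saturated chain carbon bound to a carbon with a double bond to nitrogen and a saturated chain carbon. Among the measured compounds shown here, no measured step touches that chain carbon; the only step known, a 1.5-fold higher number from compound 1 to compound 2 (0.17 log units; within the scatter), changes a group on a different part of the molecule, and it stayed within the scatter. For the measured compounds named here, because of a 1.5-fold higher number from compound 1 to compound 2 (0.17 log units; within the scatter) the one small change seen so far has left the dose for half-maximal effect unmoved, and a single added methyl on the chain gives no reason to expect more. The step of a 1.1-fold lower number from compound 2 to compound 3 (0.04 log units; within the scatter) is therefore expected to stay within the scatter. For compound 3 the estimated result in this assay is 80 mg/kg, with a range from 40 mg/kg to 160 mg/kg.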

Compound 3, dose for half-maximal effect: 28.1 mg/kg
The estimate for compound 3 lay 2.8-fold (0.45 log units) above the measured number, and the stated range ends above it.
By their numbers in this assay, from the lowest: compound 3; then compounds 1 and 2 (each within the scatter of the next).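

In this assay, methyl in place of hydrogen on this saturated chain carbon gives a 3.1-fold lower number from compound 2 to compound 3 (0.49 log units; beyond the scatter), a modest change but the first in this small set to lie beyond the scatter, so this chain carbon is a place where a single added carbon can alter the dose required. Among these compounds, the other comparison gives a 2.1-fold lower number from compound 1 to compound 3 (0.32 log units; beyond the scatter), also modest and beyond the scatter, which makes compound 3 the one needing the least compound of the three, while compound 1 and compound 2 remain within the scatter of each other. Nothing available explains why the added methyl has this effect on the dose in the whole animal.

With only hydrogen and methyl shown at this chain carbon, it remains open whether an ethyl group or a longer chain would lower the number further, raise it again, or leave it unchanged. On these data alone, it is also open whether a hydroxyl group or an amine at the same carbon would give a similar step, and whether the step holds when the group that distinguishes compound 1 from compound 2 is changed as well.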